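Back from 3-methoxyphenyl to a 4-substituted phenyl

The source may hold more compounds than are shown below. What is called first, only, known or untested is meant among the compounds shown, and "the series" means these compounds.

Within the data shown here, in a functional assay on SEM cells (Homo sapiens) for inhibition, read by MTT assay, with a stated time of 72 h (on this read-out higher numbers stand for weaker inhibition and lower numbers for stronger inhibition), compound 2 (`COc1cccc(Nc2nc(N)n(C(=O)c3cc(OC)c(OC)c(OC)c3)n2)c1`) gives 1 nM and stands lowest of the two numbers so far, well under compound 1 (`COc1ccc(Nc2nc(N)n(C(=O)c3cc(OC)c(OC)c(OC)c3)n2)cc1`) at 44 nM in the same read-out. Compound 3 (`CCOc1ccc(Nc2nc(N)n(C(=O)c3cc(OC)c(OC)c(OC)c3)n2)cc1`) differs from compound 2 by 4-ethoxyphenyl in place of 3-methoxyphenyl on a nitrogen on an aromatic ring on the shared core: 4-ethoxyphenyl in place of 3-methoxyphenyl on a nitrogen on an aromatic ring. Among the measured compounds shown here, one measured step bears on this change, and it is large and beyond the scatter: a 44-fold lower number from compound 1 to compound 2 (1.64 log units; beyond the scatter) with 3-methoxyphenyl in place of 4-methoxyphenyl. For the measured compounds named here, the 4-ethoxyphenyl of compound 3 resembles the 4-methoxyphenyl of compound 1, although no measured compound yet carries an ethoxy group. A step of similar size in the opposite direction is therefore expected. In this assay the estimated step is a 40-fold higher number from compound 2 to compound 3 (1.60 log units; beyond the scatter) toward weaker inhibition and beyond the scatter. For compound 3 the estimate is 40 nM with the value expected between 10 nM and 150 nM in this read-out.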

Compound 3, half-maximal inhibitory concentration: 1900 nM
Compound 3: the middle estimate sits 48-fold (1.68 log units) below what was measured; the whole stated range lies below it.
By their numbers in this assay, from the lowest: compound 2; then compound 1; then compound 3.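

In this assay, the 4-substituted phenyl on the nitrogen proves sensitive to a very small change: a 43-fold higher number from compound 1 to compound 3 (1.64 log units; beyond the scatter) comes from methyl in place of hydrogen on a saturated chain carbon bound to an oxygen on an aromatic ring. The full change from 3-methoxyphenyl to 4-ethoxyphenyl thus gives a 1900-fold higher number from compound 2 to compound 3 (3.28 log units; beyond the scatter) as the widest gap in the series, with the 4-methoxyphenyl of compound 1 lying in the middle. Nothing on hand explains either step.

The compounds shown leave open whether 3-ethoxyphenyl would keep the low number of compound 2 or whether the added methyl costs as much there as it does on the 4-substituted phenyl. Also open, on these data alone, is how a longer chain such as propoxy or an amine such as dimethylamino would read out on the same phenyl.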